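Replacing 4-chlorophenyl in a cytotoxic series

The compounds below may be only part of what the source reports. "The series", "measured", "known", "first", "only" and "open" are said of these compounds alone.

In a functional assay on MCF7 cells (Homo sapiens) for cytotoxicity, read by MTT assay, with a stated time of 72 h (on this read-out lower numbers stand for stronger inhibition and higher numbers for weaker inhibition), compound 1 (`COc1ccc(/C=C2\CCC/C(=C\c3cccc(OC)c3OC)C2=O)c(OC)c1`) gives > 20000 nM, which is a limit of the assay and not a number. Among the compounds with values here, compound 2 (`COc1ccc(/C=C2\CCC/C(=C\c3ccc(Cl)cc3)C2=O)cc1OC`) gives 6300 nM, the only actual number so far. Compound 3 (`COc1cccc(/C=C2\CCC/C(=C\c3ccc(OC)c(OC)c3)C2=O)c1`) has 3-methoxyphenyl in place of 4-chlorophenyl on a double-bonded chain carbon bound to a double-bonded ring carbon. Within the data shown here, no measured step between compounds differing in one place is available to size this change in this assay. A modest shift towards weaker inhibition is expected, estimated as a 1.6-fold higher number from compound 2 to compound 3 (0.20 log units; within the scatter). Compound 3 is expected to give 10000 nM, within an estimated range of 4000 nM to 20000 nM.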

Compound 3, half-maximal inhibitory concentration: 4600 nM
Compound 3: middle estimate off by 2.2-fold (0.34 log units), on the high side; low and high end bracket the measured number.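

In this assay, the exchange of 4-chlorophenyl for 3-methoxyphenyl gives the first step read at this position: a 1.4-fold lower number from compound 2 to compound 3 (0.14 log units; within the scatter). Compound 3 therefore holds a measured number with the new group, and the swap of a chlorine-bearing ring for a methoxy-bearing one, with its added hydrogen-bond acceptor, does not separate the two compounds beyond the scatter. No measurement shown bears on why they read so closely. Still open, going by these compounds, is whether an amine or a carboxylic acid at this position would move the number beyond the scatter.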